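The source may report more compounds than this note shows. Statements on the series, on what has been measured and on what is new or still open speak of the compounds shown alone.

Working notes on the series. In an ADME assay on L02 cells (Homo sapiens) for cytotoxicity, read by MTT assay, with a stated time of 72 h (a lower number here means a stronger inhibitor, a higher number a weaker inhibitor), compound 1 (`O=C(O)CCC(=O)OCCOc1no[n+]([O-])c1S(=O)(=O)c1ccccc1`) gives 36000 nM while compound 2 (`O=C(O)CCCC(=O)OCCOc1no[n+]([O-])c1S(=O)(=O)c1ccccc1`) gives 32000 nM and compound 3 (`O=C(O)CCC(=O)OCCCOc1no[n+]([O-])c1S(=O)(=O)c1ccccc1`) gives 29000 nM as its value. Compound 2 stands among these three with nothing to separate it from either of the others, since its steps to both lie within the scatter.

The open case is compound 4 (`O=C(O)c1ccccc1C(=O)OCCOc1no[n+]([O-])c1S(=O)(=O)c1ccccc1`), which differs from compound 2 in one place, with 2-carboxyphenyl in place of 3-carboxypropyl on a carbonyl carbon. The closest measured step is the change on the acid side (a 1.1-fold lower number from compound 1 to compound 2 (0.05 log units; within the scatter)), and the two changes on the other side of the ester (a 1.2-fold lower number from compound 1 to compound 3 (0.09 log units; within the scatter)) and (a 1.1-fold lower number from compound 2 to compound 3 (0.04 log units; within the scatter)) add to it. All three are small and within the scatter. From the compounds shown here alone, none of them brings in an aromatic ring, so the entering group itself is untested here, and the range has to stay wide.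

Resting on compound 2 (32000 nM) and these steps, no step beyond the scatter is expected in this assay in either direction. The expected result is a 1.1-fold lower number from compound 2 to compound 4 (0.03 log units; within the scatter) as an estimate only. The estimate for compound 4 is 30000 nM with an expected range from 13000 nM up to 65000 nM around it.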

Compound 4, half-maximal inhibitory concentration: 37000 nM
Beside the measured number, compound 4's estimate is 1.2-fold (0.09 log units) below it; the range from low to high includes it.
By their numbers in this assay, from the lowest: compounds 3, 2, 1 and 4 (each within the scatter of the next).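

In this assay, among the compounds shown here, the earlier compounds varied only saturated chains, and compound 4 adds the first aromatic group on this carbonyl carbon. Putting 2-carboxyphenyl in place of 3-carboxypropyl gives a step within the scatter (a 1.2-fold higher number from compound 2 to compound 4 (0.06 log units; within the scatter)), and putting it in place of 2-carboxyethyl does the same (a 1.0-fold higher number from compound 1 to compound 4 (0.01 log units; within the scatter)), so at this position, neither the added ring nor the larger group separates compound 4 from the compounds with saturated chains. Nothing measured here offers a reason for this result.

From the compounds shown here alone, all four compounds carry a carboxylic acid on this group, so it remains open whether the number would move if an amine, a methyl ester or a simple unsubstituted phenyl took the place of that acid-bearing group. Going by these compounds, a chain longer than 3-carboxypropyl and a phenyl ring carrying fluorine or methoxy alongside the acid also remain open, as does whether any change at this position can produce a step beyond the scatter.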